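From thiophen-3-yl to 1H-indol-3-yl at the carbonyl

The source may hold more compounds than are shown below. What is called first, only, known or untested is meant among the compounds shown, and "the series" means these compounds.

Compound 1, `COc1ccc(-c2cc3ccccc3nc2/C=C/C(=O)c2ccc(F)cc2)cc1`: > 10000 nM
Compound 2, `COc1ccc(-c2cc3ccccc3nc2/C=C/C(=O)c2ccc([N+](=O)[O-])cc2)cc1`: 6100 nM
Compound 3, `COc1ccc(-c2cc3ccccc3nc2/C=C/C(=O)c2ccsc2)cc1`: 6390 nM

Of the compounds shown here, three sharing one core have been tested in a functional assay on H184B5F5/M10 cells (Homo sapiens) for antiproliferative activity, read by XTT assay, with a stated time of 72 h; a higher number here means a weaker inhibitor, a lower number a stronger inhibitor. For compound 1 the result is a limit of the assay, > 10000 nM, not a number (the limit of > 10000 nM in this assay, at which 1 of the 3 values shown sits). Compound 2 gives 6100 nM, and compound 3 gives 6390 nM. Among the two numbers, compound 3 has the higher one, but its nearest neighbour is compound 2 and the gap between them, a 1.0-fold higher number from compound 2 to compound 3 (0.02 log units; within the scatter), is within the scatter. The step of an at least 1.5-fold lower number from compound 1 to compound 3 (0.19 log units; that floor lies within the scatter) starts from a limit, so its floor also lies within the scatter.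

Compound 4, `COc1ccc(-c2cc3ccccc3nc2/C=C/C(=O)c2c[nH]c3ccccc23)cc1`, has not yet been measured. It differs from compound 3 in one place: 1H-indol-3-yl in place of thiophen-3-yl on a carbonyl carbon. Within the data shown here, the steps that bear on this change are the two that also alter the group on the carbonyl carbon, an at least 1.5-fold lower number from compound 1 to compound 3 (0.19 log units; that floor lies within the scatter) and a 1.0-fold higher number from compound 2 to compound 3 (0.02 log units; within the scatter); neither moves the number beyond the scatter. On that basis no step beyond the scatter is expected from compound 3 to compound 4, a 1.2-fold lower number from compound 3 to compound 4 (0.07 log units; within the scatter). Compound 4 is therefore expected to give about 5500 nM, with a range from 1500 nM to 20000 nM.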

Compound 4, half-maximal inhibitory concentration: > 10000 nM
Compound 4 gave a limit, no number; the forecaster's own chance of this, stated with the estimate: 30%; middle value at least 1.8-fold (0.25 log units) away from the limit.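

In this assay compound 4 gives > 10000 nM, which is a limit of the assay and not a number, and this places it with compound 1: the limit of > 10000 nM in this assay, at which 2 of the 4 values shown sit. Placing 1H-indol-3-yl on the carbonyl carbon gives an at least 1.5-fold higher number from compound 3 to compound 4 (0.19 log units; that floor lies within the scatter) and an at least 1.6-fold higher number from compound 2 to compound 4 (0.21 log units; that floor lies within the scatter), so neither floor shows a change beyond the scatter, yet the position has now taken a group with a six-membered aromatic ring of carbon only joined to its five-membered aromatic ring, and a hydrogen-bond donor, and the result sits at the limit rather than at a readable number. The step between compound 1 and compound 4 cannot be read, since both ends of it are limits.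

The compounds shown leave open how far the true value of compound 4 lies from those of compound 2 and compound 3, and whether the added ring or the hydrogen-bond donor goes with the result. A 1H-pyrrol-3-yl group, which keeps the donor without the second ring, and a benzothiophen-3-yl group, which keeps the second ring without the donor, would separate the two on the same carbonyl carbon.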